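A methyl added to the pyridinyl arm of compound 2

A few compounds are considered here, and "the series" means these few. Any claim that something is new, unique, unknown or untested is made for them only; others in the source may bear on it.

Among the measured compounds shown here, compound 2 `Fc1cc(-c2ccccn2)cc(-n2nnc(-c3ccccn3)n2)c1` gives 95 nM in an assay for binding affinity to metabotropic glutamate receptor 5 (Rattus norvegicus) (a lower number here means a stronger inhibitor, a higher number a weaker inhibitor), the higher of the two numbers known here; its nearest neighbour, compound 1 `Nc1ccccc1-c1cc(F)cc(-n2nnc(-c3ccccn3)n2)c1`, gives 7 nM, and a 14-fold higher number from compound 1 to compound 2 (1.13 log units; beyond the scatter). Compound 3 `Cc1cccnc1-c1cc(F)cc(-n2nnc(-c3ccccn3)n2)c1` differs from compound 2 by methyl in place of hydrogen on an aromatic carbon. For the measured compounds named here, no measured step covers this change; the single known step exchanges the whole arm and tells nothing about a methyl on it. Compound 3 is therefore expected to move only modestly, a 1.4-fold lower number from compound 2 to compound 3 (0.13 log units; within the scatter), and is estimated at 70 nM in this assay, within 15 nM to 300 nM.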

Compound 3, inhibition constant: 24 nM
Compound 3: middle estimate off by 2.9-fold (0.46 log units), on the high side; measured number inside the range.
By their numbers in this assay, from the lowest: compound 1; then compound 3; then compound 2.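

Methyl in place of hydrogen on the pyridinyl arm, ortho to a large group and two atoms from the ring nitrogen, moves the number beyond the scatter, with a 4.0-fold lower number from compound 2 to compound 3 (0.60 log units; beyond the scatter) in this assay. This single added carbon regains only part of the ground held by the 2-aminophenyl arm, leaving a 3.4-fold higher number from compound 1 to compound 3 (0.54 log units; beyond the scatter). Nothing available here accounts for the gain. Open, going by these compounds, is whether ethyl, methoxy or chlorine on this carbon would act like methyl. Also open, on these data alone, is whether an amine on the pyridinyl arm would close the remaining gap.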